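The source may hold more compounds than are shown below. What is called first, only, known or untested is meant among the compounds shown, and "the series" means these compounds.

Compound 1 `CC(=O)N1N=C(c2ccc3ccccc3c2)OC1c1ccccc1Cl`: 2.36 ug/mL
Compound 2 `CC(=O)N1N=C(c2ccc3ccccc3c2)OC1c1ccc(Cl)cc1`: 2.63 ug/mL
Compound 3 `CC(=O)N1N=C(c2ccc3ccccc3c2)OC1c1ccccc1O`: 2.12 ug/mL

All three values come from a functional assay on MCF7 cells (Homo sapiens) for antiproliferative activity, read by MTT assay, with a stated time of 48 h (on this read-out lower numbers stand for stronger inhibition and higher numbers for weaker inhibition), and the compounds share one core, differing only in the group on a saturated ring carbon. Compound 3 gives 2.12 ug/mL in this test, which cannot be told apart from the other two values once the normal spread of repeat measurements is allowed for.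

The next compound is compound 4 `CC(=O)N1N=C(c2ccc3ccccc3c2)OC1c1ccccn1`. The change is pyridin-2-yl in place of 2-hydroxyphenyl on a saturated ring carbon (in words: pyridin-2-yl in place of 2-hydroxyphenyl on a saturated ring carbon). For the measured compounds named here, no measured compound has a hetero atom in the aromatic ring at this place, so the data offer only indirect guidance.

That guidance comes from three swaps at this same carbon or on its ring: a 1.1-fold higher number from compound 1 to compound 2 (0.05 log units; within the scatter) and a 1.1-fold lower number from compound 1 to compound 3 (0.05 log units; within the scatter) and a 1.2-fold lower number from compound 2 to compound 3 (0.09 log units; within the scatter) all stayed small. On that basis, no step beyond the scatter is expected in this assay and neither direction is favoured. The expected step is a 1.1-fold higher number from compound 3 to compound 4 (0.05 log units; within the scatter) and it rests on thin evidence. For compound 4 the estimate is 2.4 ug/mL with an expected range from 1.1 ug/mL to 5 ug/mL in this test.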

Compound 4, half-maximal inhibitory concentration: 6.02 ug/mL
Compound 4: middle estimate off by 2.5-fold (0.40 log units), on the low side, and the stated range ends below it.
By their numbers in this assay, from the lowest: compounds 3, 1 and 2 (each within the scatter of the next); then compound 4.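

In this assay the saturated ring carbon proves less forgiving than the earlier swaps suggested: bringing in pyridin-2-yl gives a 2.8-fold higher number from compound 3 to compound 4 (0.45 log units; beyond the scatter) and a 2.3-fold higher number from compound 2 to compound 4 (0.36 log units; beyond the scatter) and also a 2.6-fold higher number from compound 1 to compound 4 (0.41 log units; beyond the scatter) in this series. The three compounds with a ring of carbon only at this place, compound 1, compound 2 and compound 3, lie within the scatter of one another, while compound 4, the only one with a hetero atom in that ring, stands apart with weaker inhibition, so the aromatic ring here cannot be exchanged freely. Nothing available gives a reason for this step.

Compound 4 differs from the others in two ways at once, since its ring gains a nitrogen and carries neither chloro nor hydroxy, and a plain phenyl group on this carbon would be needed to separate those two changes. On these data alone, whether the place of the ring nitrogen matters also stays open, and pyridin-3-yl and pyridin-4-yl are the groups that would answer it.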